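Methyl to Chloro: A Step from Compound 2

The source may report more compounds than this note shows. Statements on the series, on what has been measured and on what is new or still open speak of the compounds shown alone.

Compound 1 `CC(C(=O)N1CCN(c2ccc(F)cc2)CC1)N1C(=O)CCC1=O`: 50%
Compound 2 `Cc1cccc(N2CCN(C(=O)C(C)N3C(=O)CCC3=O)CC2)c1`: 0%

In a functional assay on the whole organism (strain Swiss) with Mus musculus as the target, in the maximal electroshock model, with a stated time of 2 h, at a dose of 300 mg/kg by the intraperitoneal route (a higher number here means a stronger effect of the compound at the dose given, a lower number a weaker effect), compound 1 gives 50%, whereas compound 2 gives 0%. Compound 2 therefore stands lowest of the two numbers, its nearest neighbour being compound 1, and the step of a number 50 percentage points lower from compound 1 to compound 2 (beyond the scatter) is well beyond the scatter. Compound 3 `CC(C(=O)N1CCN(c2cccc(Cl)c2)CC1)N1C(=O)CCC1=O` has not yet been measured. It differs from compound 2 by chloro in place of methyl on an aromatic carbon. Among the measured compounds shown here, the only measured step concerns a different change, 3-methylphenyl in place of 4-fluorophenyl, so it shows how much the group on that ring can matter but does not tell whether chloro will resemble methyl or fluoro. The direction is thus uncertain, with only a modest recovery anticipated. Compound 3 is expected to give 25%, within 0% to 60%, which means an estimated step of a number 25 percentage points higher from compound 2 to compound 3 (beyond the scatter).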

Compound 3, a percentage reported as activity, at one dose (the size of the read-out at that dose, not a potency): 50%
The estimate for compound 3 lay 25 percentage points below the measured number; the range from low to high includes it.
By their numbers in this assay, from the lowest: compound 2; then compounds 1 and 3 (each within the scatter of the next).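

In this assay, the exchange of methyl for chloro on this aromatic carbon, one heavy atom for one, gives a number 50 percentage points higher from compound 2 to compound 3 (beyond the scatter), so this single place can decide the read-out at the dose given. The earlier step changed the group and its place on the ring together, whereas this one changes only the group, and the further comparison gives no change at the digits printed from compound 1 to compound 3 (within the scatter), which leaves 3-chlorophenyl and 4-fluorophenyl indistinguishable here, with 3-methylphenyl alone giving the low number among these compounds. No measurement shown here accounts for the difference between methyl and chloro.

From the compounds shown here alone, whether a methoxy or a trifluoromethyl group on the same aromatic carbon would go with chloro or with methyl stays open. So does whether compounds that match at this one dose would also match at other doses.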